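This account rests on a few compounds, and the source may have more. Where it says the series, first, only, none or still open, it means among the compounds named here.

Of the compounds shown here, three built on a shared core have been measured in a functional assay (brain) for inhibition, with Rattus norvegicus as the target; a higher number here means a weaker inhibitor, a lower number a stronger inhibitor. Compound 1 `Cc1c(C)c2c(c(C)c1O)CCC(C)(CC(=O)N1CCN(c3cc(N4CCCC4)nc(N4CCCC4)n3)CC1)O2` gives 1300 nM in this assay. Compound 2 `CC(=O)Oc1c(C)c(C)c2c(c1C)CCC(C)(CN1CCN(c3cc(N4CCCC4)nc(N4CCCC4)n3)CC1)O2` gives 1500 nM in this assay. Compound 3 `CCNc1cccnc1N1CCN(CC2(C)CCc3c(C)c(O)c(C)c(C)c3O2)CC1` gives 1000 nM in this assay, the lowest of the three numbers, though its gaps to compound 1 and to compound 2 both fall within the usual scatter, so the three numbers cannot be told apart.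

Compound 4 `Cc1c(C)c2c(c(C)c1O)CCC(C)(CN1CCN(c3ccc(Cl)cc3)CC1)O2` has not been measured. It differs from compound 3 in one place: 4-chlorophenyl in place of 3-(ethylamino)pyridin-2-yl on an amine nitrogen in a ring. For the measured compounds named here, no pair of measured compounds isolates this change, so nothing in the measured set shows how this assay responds to it. What the set does show is that compound 1 and compound 2, each differing from compound 3 in more than one place, still give numbers within the scatter of compound 3; the series looks flat across the measured changes. On that basis the account expects compound 4 to stay near compound 3, with no step beyond the scatter. The expected step is a 1.5-fold higher number from compound 3 to compound 4 (0.18 log units; within the scatter). Compound 4 is estimated to give 1500 nM in this assay, within a range from 500 nM to 5000 nM.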

Compound 4, half-maximal inhibitory concentration: 900 nM
Compound 4: the middle estimate sits 1.7-fold (0.22 log units) above what was measured; measured number inside the range.
By their numbers in this assay, from the lowest: compounds 4, 3, 1 and 2 (each within the scatter of the next).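

In this assay, for the compounds shown here, the exchange of 3-(ethylamino)pyridin-2-yl for 4-chlorophenyl on an amine nitrogen in a ring gives a 1.1-fold lower number from compound 3 to compound 4 (0.05 log units; within the scatter) and is the only single-place step in the set, so the response at this position can now be read directly rather than inferred from compounds that differ in several places. The group that leaves carries a hydrogen-bond donor, hydrogen-bond acceptors and a hetero atom in its ring, while the group that enters carries none of these, and for this one pair their loss comes with no step beyond the scatter. Nothing at hand explains why the number holds across this change.

As far as these compounds go, whether the reading stays the same with a carboxylic acid or a dimethylamino group in place of the chlorine, or with a saturated piperidine ring in place of the aromatic ring, remains open. Also open, from the compounds shown here alone, is whether 4-chlorophenyl would read the same alongside the carbonyl link of compound 1 or the acetyl ester of compound 2.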